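This account rests on a few compounds, and the source may have more. Where it says the series, first, only, none or still open, it means among the compounds named here.

Measured so far:
compound 1, `COc1cccc(Sc2c(NS(=O)(=O)c3ccc(C(C)(C)C)cc3)noc2CCC/C=N/O)c1` — in an assay on COS-7 cells for displacement of a labelled ligand from Endothelin receptor type B (Sus scrofa) (on this read-out higher numbers stand for weaker inhibition and lower numbers for stronger inhibition), compound 1 gives 85 nM
compound 2, `COc1cccc(Sc2c(NS(=O)(=O)c3ccc(C(C)(C)C)cc3)noc2CCCC(=O)O)c1` — in this assay compound 2 gives 500 nM

Compound 2 stands at the higher of the two numbers in this assay. For the measured compounds named here, the only measured step, a 5.9-fold higher number from compound 1 to compound 2 (0.77 log units; beyond the scatter), sets it apart from compound 1 by more than the scatter.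

Compound 3, `COc1cccc(Sc2c(NS(=O)(=O)c3ccc(C(C)(C)C)cc3)noc2CCCC(C)=O)c1`, is not yet measured. It differs from compound 2 by methyl in place of hydroxy on a carbonyl carbon, so the carboxy end of compound 2 becomes an acetyl end. Going by the values given here, no measured step covers this change directly. The step of a 5.9-fold higher number from compound 1 to compound 2 (0.77 log units; beyond the scatter) bears on it only loosely: it shows that altering the end of this chain moved the number in this assay well beyond the scatter, but it compares the end group of compound 1 with a carboxy end, not with an acetyl end. Compound 3 removes the carboxy end that compound 2 carries, and a modest move toward the number of compound 1 is expected, with wide uncertainty. Compound 3 is estimated at 200 nM, range 60 nM to 700 nM; the expected step is a 2.5-fold lower number from compound 2 to compound 3 (0.40 log units; beyond the scatter).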

Compound 3, half-maximal inhibitory concentration: 400 nM
Beside the measured number, compound 3's estimate is 2.0-fold (0.30 log units) below it; the measured number falls inside the stated range.
By their numbers in this assay, from the lowest: compound 1; then compounds 3 and 2 (each within the scatter of the next).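

In this assay, methyl in place of hydroxy on a carbonyl carbon gives a 1.3-fold lower number from compound 2 to compound 3 (0.10 log units; within the scatter), so the carboxy end and the acetyl end cannot be told apart at this position, and the hydroxy, with the hydrogen-bond donor counted on it, shows no measurable contribution to this read-out in this pair. The separation from the end group of compound 1 survives this change, at a 4.7-fold higher number from compound 1 to compound 3 (0.67 log units; beyond the scatter), so compound 1 now stands apart from two different carbonyl ends by more than the scatter, and the gap seen with compound 2 is not particular to the carboxy end. No measurement shown here accounts for this separation or for the absence of a resolved step between the two carbonyl ends.

Still open, on these data alone, is whether an amide, a primary alcohol or an amine at the end of this chain would stay with compound 2 and compound 3 or come close to compound 1, which gives 85 nM. Also open, as far as these compounds go, is whether a shorter or longer chain would change the size of the gap between the end group of compound 1 and the carbonyl ends.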